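This account rests on a few compounds, and the source may have more. Where it says the series, first, only, none or still open, it means among the compounds named here.

Of the compounds shown here, two carry numbers so far. Compound 1 `COc1ccccc1N1C(=O)CSC1c1cccc(C(=O)NCCCCc2ccc(Cl)cc2)c1` gives 78.6 nM in a functional assay on HOS-TE85 cells (Homo sapiens) for inhibition, read by CCK-8 assay, with a stated time of 72 h; on this read-out higher numbers stand for weaker inhibition and lower numbers for stronger inhibition. Among the measured compounds shown here, compound 2 `O=C(NCCCCc1ccccc1)c1cccc(C2SCC(=O)N2c2ccccc2)c1` gives 15.9 nM in this assay and so stands lowest of the two numbers, with compound 1 the only other value and well beyond the usual scatter from it; the two differ in more than one place, so the gap cannot be tied to a single change. Compound 3 `O=C(NCCCCc1ccccc1)c1cccc(C2SCC(=O)N2c2cccc(F)c2)c1` is not yet measured. It differs from compound 2 by fluoro in place of hydrogen on an aromatic carbon. For the measured compounds named here, no pair of measured compounds shows what this change does here. In this assay a step no larger than the usual scatter, in either direction, is expected. Compound 3 is expected to give 18 nM in this assay, with an estimated range from 7 nM to 45 nM. The estimated step is a 1.1-fold higher number from compound 2 to compound 3 (0.05 log units; within the scatter).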

Compound 3, half-maximal inhibitory concentration: 32.4 nM
Compound 3: middle estimate off by 1.8-fold (0.26 log units), on the low side, and the stated range covers the measured number.
By their numbers in this assay, from the lowest: compound 2; then compound 3; then compound 1.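

In this assay, among the compounds shown here, the change from phenyl to 3-fluorophenyl gives the first step that can be tied to a single place: a 2.0-fold higher number from compound 2 to compound 3 (0.31 log units; beyond the scatter). A single fluoro, meta to a large group, is thus enough to shift the number, and the shift runs towards weaker inhibition, modest in size but beyond the scatter. Nothing on hand accounts for this step.

The series offers only this one substituent at this place, so it gives no trend across groups and does not show whether the loss is particular to fluoro. Going by these compounds, how a nitrile, an amine or a carboxylic acid would read at this same place remains open, as does the effect of fluoro elsewhere on this ring.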